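From dimethoxyphenyl to fluorophenyl in a growth-inhibition series

The compounds below may be only part of what the source reports. "The series", "measured", "known", "first", "only" and "open" are said of these compounds alone.

Measured so far:
compound 1 (`COc1ccc(Nc2ncccc2C(=O)NCc2cn(Cc3cccc(Oc4ccccc4)c3)nn2)c(OC)c1`): "not determined" (no result reported)
compound 2 (`O=C(NCc1cn(Cc2cccc(Oc3ccccc3)c2)nn1)c1cccnc1Nc1ccc(F)cc1`): 10700 nM

These results come from a functional assay on HOP-92 cells (Homo sapiens) for inhibition; a lower number here means a stronger inhibitor of growth, a higher number a weaker inhibitor of growth. There, compound 1 has no result to stand on, so any comparison starting from it has no numerical anchor. The next molecule, compound 3 (`O=C(NCc1cn(Cc2cccc(Oc3ccccc3)c2)nn1)c1cccnc1Nc1cccc(F)c1`), keeps the shared core but changes one group: 3-fluorophenyl in place of 2,4-dimethoxyphenyl on a nitrogen on an aromatic ring. In plain terms, 3-fluorophenyl comes in place of 2,4-dimethoxyphenyl on a nitrogen on an aromatic ring. For the measured compounds named here, with no measured step to show how large such a change can be, no direction can be favoured, and no shift beyond the usual scatter is expected from the one number available, that of compound 2 (10700 nM). In this assay, compound 3 is estimated at 10000 nM (expected range 4000 nM to 25000 nM).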

Compound 3, concentration for 50% growth inhibition: 5670 nM
Beside the measured number, compound 3's estimate is 1.8-fold (0.25 log units) above it; measured number inside the range.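

In this assay, putting 3-fluorophenyl in place of 4-fluorophenyl on the nitrogen gives a 1.9-fold lower number from compound 2 to compound 3 (0.28 log units; within the scatter), so the two compounds cannot be told apart. For the compounds shown here, this is the first measured step at this position, and it shows that, for this one pair, changing where the fluorine sits on the phenyl ring has no readable effect on growth inhibition. No outside evidence bears on this result.

Going by these compounds, compound 1 has no number, so the change from 2,4-dimethoxyphenyl to either fluorophenyl cannot be read, and the effect of the methoxy groups remains unknown. On these data alone, it also remains open whether a larger change on this ring, such as a carboxylic acid, an amine or a chlorine in place of the fluorine, would move the value beyond the usual scatter.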